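This account rests on a few compounds, and the source may have more. Where it says the series, first, only, none or still open, it means among the compounds named here.

Measured compounds:
compound 1, `FC(F)(F)c1ccc(CSc2nc(Nc3ccccc3C(F)(F)F)c3ccccc3n2)cc1`, gives 34800 nM
compound 2, `FC(F)(F)c1ccc(CSc2nc(Nc3ccccc3Cl)c3ccccc3n2)cc1`, gives 20400 nM
compound 3, `FC(F)(F)c1ccc(CSc2nc(Nc3cccc(Cl)c3)c3ccccc3n2)cc1`, gives 13400 nM

These values come from a functional assay on PC-3 cells (Homo sapiens) for cytotoxicity, read by MTT assay, with a stated time of 72 h; a lower number here means a stronger inhibitor, a higher number a weaker inhibitor. Compound 2 sits second highest of the three numbers, separated from compound 3 by a 1.5-fold lower number from compound 2 to compound 3 (0.18 log units; within the scatter) and from compound 1 by a 1.7-fold lower number from compound 1 to compound 2 (0.23 log units; within the scatter). Compound 4, `O=[N+]([O-])c1ccc(Nc2nc(SCc3ccc(C(F)(F)F)cc3)nc3ccccc23)cc1`, is not yet measured; it differs from compound 2 by 4-nitrophenyl in place of 2-chlorophenyl on a nitrogen on an aromatic ring. Within the data shown here, the steps that bear on this change all alter the group on the same nitrogen: a 1.7-fold lower number from compound 1 to compound 2 (0.23 log units; within the scatter), a 1.5-fold lower number from compound 2 to compound 3 (0.18 log units; within the scatter) and a 2.6-fold lower number from compound 1 to compound 3 (0.41 log units; beyond the scatter), the last one modest, the others within the scatter. A similarly small step is therefore expected, a 1.4-fold lower number from compound 2 to compound 4 (0.13 log units; within the scatter), possibly toward a lower number. Compound 4 is estimated at 15000 nM, within 5000 nM to 45000 nM.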

Compound 4, half-maximal inhibitory concentration: 7900 nM
Compound 4: the middle estimate sits 1.9-fold (0.28 log units) above what was measured; measured number inside the range.
By their numbers in this assay, from the lowest: compounds 4, 3, 2 and 1 (each within the scatter of the next, the first and the last beyond it).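

Unlike 3-chlorophenyl, 4-nitrophenyl on this nitrogen gives a step from the 2-chlorophenyl compound that lies beyond the scatter in this assay: a 2.6-fold lower number from compound 2 to compound 4 (0.41 log units; beyond the scatter). The step from the 2-(trifluoromethyl)phenyl compound is larger, a 4.4-fold lower number from compound 1 to compound 4 (0.64 log units; beyond the scatter), while a 1.7-fold lower number from compound 3 to compound 4 (0.23 log units; within the scatter), so these two groups cannot be told apart here. No measurement shown gives a reason for these steps.

The compounds shown leave open whether the nitro group itself or its place on the ring matters. A 4-chlorophenyl or 4-aminophenyl group on the same nitrogen would bear on that question.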